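A few compounds are considered here, and "the series" means these few. Any claim that something is new, unique, unknown or untested is made for them only; others in the source may bear on it.

Compound 2 `CC(C(=O)N1CCN(c2ccccc2F)CC1)N1C(=O)CCC1=O` and compound 1 `CCC(C(=O)N1CCN(c2cccc(F)c2)CC1)N1C(=O)CCC1=O` have both been run in a functional assay on the whole organism (strain Swiss) with Mus musculus as the target, in the maximal electroshock model, with a stated time of 0.25 h, at a dose of 300 mg/kg by the intraperitoneal route; a higher number here means a stronger effect of the compound at the dose given, a lower number a weaker effect. In this assay compound 2 gives 100%, the highest of the two numbers, while compound 1 gives 75%, a figure lower by an amount beyond the usual scatter. Compound 3 `CCC(C(=O)N1CCN(c2ccccc2F)CC1)N1C(=O)CCC1=O` awaits measurement. Its difference from compound 2 is methyl in place of hydrogen on a saturated chain carbon, two bonds along the chain from an amide-type nitrogen in a ring and a carbonyl carbon. Among the measured compounds shown here, no measured pair shows this change on its own, so its effect is open. The step expected from compound 2 to compound 3 is a number 12 percentage points lower from compound 2 to compound 3 (beyond the scatter), a small drop at most. Compound 3 is therefore expected to give 88%, in a range from 60% to 100%.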

Compound 3, a percentage reported as activity, at one dose (the size of the read-out at that dose, not a potency): 100%
The estimate for compound 3 lay 12 percentage points below the measured number; the measured number falls inside the stated range.
By their numbers in this assay, from the lowest: compound 1; then compounds 2 and 3 (each within the scatter of the next).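

In this assay, methyl in place of hydrogen on a saturated chain carbon, two bonds along the chain from an amide-type nitrogen in a ring and a carbonyl carbon, shows no change at the digits printed from compound 2 to compound 3 (within the scatter), so this position accepts the change at this dose. With that methyl present in both compounds, 2-fluorophenyl in place of 3-fluorophenyl on an amine nitrogen in a ring gives a number 25 percentage points higher from compound 1 to compound 3 (beyond the scatter). Nothing available here accounts for either step.

From the compounds shown here alone, whether a propyl group at the same carbon, or chlorine in place of the fluorine, would keep the effect remains open. A read-out at one dose also leaves the potency of compound 2 and compound 3 unresolved.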